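Amide nitrogen substituent change and clearance in the series

The source may hold more compounds than are shown below. What is called first, only, known or untested is meant among the compounds shown, and "the series" means these compounds.

Among the measured compounds shown here, in an in vitro ADME assay on microsomes from liver (Homo sapiens) for pharmacokinetics, read by LC-MS, with a stated time of 10 min, tested at 1 uM (on this read-out higher numbers stand for fast clearance and lower numbers for slow clearance), compound 1 `CN1C[C@H](C(=O)Nc2cccc(Cl)c2)[C@@H](c2ccc(/C=C/C(=O)Nc3ccccc3N)cc2)C1` gives 7 mL/min/kg; the only other number in hand, from compound 2 `CN1C[C@H](C(=O)Nc2ccc(Cl)c(Cl)c2)[C@@H](c2ccc(/C=C/C(=O)Nc3ccccc3N)cc2)C1` at 14 mL/min/kg, lies within the scatter of it, the step of a 2.0-fold higher number from compound 1 to compound 2 (0.30 log units; within the scatter) being chloro in place of hydrogen on an aromatic carbon. Compound 3 `CC(C)NC(=O)[C@H]1CN(C)C[C@@H]1c1ccc(/C=C/C(=O)Nc2ccccc2N)cc1` differs from compound 1 by isopropyl in place of 3-chlorophenyl on an amide-type nitrogen. For the measured compounds named here, no measured step touches the amide-type nitrogen, so the single step seen, which stayed within the scatter, is the only guide and gives no direction. Compound 3 is therefore expected at 7 mL/min/kg, with a range from 3 mL/min/kg to 15 mL/min/kg, a step of no change at the digits printed from compound 1 to compound 3 (within the scatter).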

Compound 3, clearance: 8 mL/min/kg
For compound 3 the middle estimate is 1.1-fold (0.06 log units) below the measured one; the range from low to high includes it.
By their numbers in this assay, from the lowest: compounds 1, 3 and 2 (each within the scatter of the next).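

In this assay, the amide-type nitrogen tolerates isopropyl in place of 3-chlorophenyl, giving a 1.1-fold higher number from compound 1 to compound 3 (0.06 log units; within the scatter), and isopropyl in place of 3,4-dichlorophenyl, giving a 1.8-fold lower number from compound 2 to compound 3 (0.24 log units; within the scatter). Across compounds 1, 2 and 3, removing the aromatic ring from this nitrogen therefore produces no clearance step beyond the scatter. No supporting data explain this result.

Still open is whether a longer chain in place of isopropyl, or a chain carrying an amine or a carboxylic acid on this nitrogen, would stay within the scatter of these compounds.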